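Methylamino for Methoxy on a Nucleoside Core

A few compounds are considered here, and "the series" means these few. Any claim that something is new, unique, unknown or untested is made for them only; others in the source may bear on it.

Measured compounds:
compound 1, `COc1ncnc2c1c(-c1ccoc1)cn2[C@@H]1O[C@H](CO)[C@@H](O)[C@H]1O`: 130 nM
compound 2, `C#Cc1cn([C@@H]2O[C@H](CO)[C@@H](O)[C@H]2O)c2ncnc(OC)c12`: 5140 nM

In a functional assay on HCT-116 cells (Homo sapiens), read by MTT assay, with a stated time of 72 h (on this read-out higher numbers stand for weaker inhibition and lower numbers for stronger inhibition), compound 1 gives 130 nM, the lowest of the two numbers; compound 2 sits a 40-fold higher number from compound 1 to compound 2 (1.60 log units; beyond the scatter) away, after ethynyl in place of furan-3-yl on an aromatic carbon. Compound 3 `CNc1ncnc2c1c(-c1ccoc1)cn2[C@@H]1O[C@H](CO)[C@@H](O)[C@H]1O` has not been measured yet. It differs from compound 1 by methylamino in place of methoxy on an aromatic carbon. Among the compounds with values here, the single measured step concerns the furan-3-yl group only, so nothing measured bears on the exchange of methoxy for methylamino. With no guidance on direction, the expected step is a 1.2-fold lower number from compound 1 to compound 3 (0.07 log units; within the scatter), within the scatter. Compound 3 is estimated at 110 nM, between 30 nM and 400 nM.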

Compound 3, half-maximal inhibitory concentration: > 20000 nM
Compound 3: only a limit was reported; the forecaster's own chance of this, stated with the estimate: 3%; at least 180-fold (2.25 log units) between middle value and limit.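

In this assay compound 3 gives > 20000 nM, which is a limit of the assay and not a number: the limit of > 20000 nM in this assay, at which 1 of the 3 values shown sits. Within the data shown here, the only earlier step varied the furan-3-yl group, whereas this step, an at least 150-fold higher number from compound 1 to compound 3 (2.18 log units; beyond the scatter), shows that the methoxy position on the shared core is also far from indifferent. A small exchange suffices here: methylamino carries a hydrogen-bond donor where methoxy has none. Going by these compounds, what a dimethylamino group, a plain amino group or an ethoxy group would give at this position stays open. Also open, on these data alone, is whether methylamino has a comparable effect alongside the ethynyl group of compound 2.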